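From 4-bromobenzyl to 3-chlorobenzyl in the series

A few compounds are considered here, and "the series" means these few. Any claim that something is new, unique, unknown or untested is made for them only; others in the source may bear on it.

In a toxicity assay on NIH3T3 cells (Mus musculus) for cytotoxicity, read by resazurin assay (a higher number here means that more compound is needed for the effect, a lower number that less compound is needed), compound 1 (`COC(=O)c1ccc(NCc2cncn2Cc2ccc(Cl)cc2)cc1-c1ccccc1`) gives 25000 nM. Within the data shown here, compound 2 (`COC(=O)c1ccc(NCc2cncn2Cc2ccc(Br)cc2)cc1-c1ccccc1`) has only a limit in this assay, > 10000 nM, and that limit is its whole standing on the numbers so far. Compound 3 (`COC(=O)c1ccc(NCc2cncn2Cc2cccc(Cl)c2)cc1-c1ccccc1`) follows from compound 2 with 3-chlorophenyl in place of 4-bromophenyl on a saturated chain carbon bound to an aromatic nitrogen. Among the measured compounds shown here, the one measured step that bears on this change is a step that the limit leaves unreadable from compound 1 to compound 2, bromo in place of chloro on an aromatic carbon, so it gives no size to carry over. For the measured compounds named here, the expectation therefore rests on compound 1 at 25000 nM, the only full number. In this assay no step beyond the scatter is expected, and the estimated move is a step that the limit leaves unreadable from compound 2 to compound 3. For compound 3 the estimated value is 20000 nM, with an expected range of 9000 nM to 45000 nM.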

Compound 3, half-maximal effective concentration: > 10000 nM
Compound 3: only a limit was reported (the forecaster's own chance of this, stated with the estimate: 35%); the middle value is on the limit's open side.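

No new step can be read among compound 1, compound 2 and compound 3, because compound 2 and compound 3 are reported only as limits: the limit of > 10000 nM in this assay, at which 2 of the 3 values shown sit.

Still open, going by these compounds, is where the 4-bromobenzyl and 3-chlorobenzyl compounds actually sit relative to compound 1 in this assay.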